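The source may report more compounds than this note shows. Statements on the series, on what has been measured and on what is new or still open speak of the compounds shown alone.

Within the data shown here, compound 3 `O=C(Nc1ccc(C(F)(F)F)cc1)c1csc(Cc2c(Cl)cccc2Cl)n1` stands at the lowest of the two numbers so far in an assay on CHO cells, read by calcium flux; on this read-out lower numbers stand for stronger inhibition and higher numbers for weaker inhibition: compound 3 gives 140 nM. Compound 1 `CC(C)(C)c1ccc(NC(=O)c2csc(Cc3c(Cl)cccc3Cl)n2)cc1` gives 570 nM in this assay, and the step is a 4.1-fold lower number from compound 1 to compound 3 (0.61 log units; beyond the scatter). For compound 2 `CN(C)c1ccc(NC(=O)c2csc(Cc3c(Cl)cccc3Cl)n2)cc1`, this assay reports only a limit, > 4000 nM, and the limit of > 4000 nM in this assay, at which 1 of the 3 values shown sits, describes this value. Against that limit the steps are an at least 7.0-fold higher number from compound 1 to compound 2 (0.84 log units; beyond the scatter) and an at least 28-fold lower number from compound 2 to compound 3 (1.45 log units; beyond the scatter).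

Compound 4 `O=C(Nc1ccc(C(F)(F)F)cc1)c1csc(CCc2c(Cl)cccc2Cl)n1` differs from compound 3 in one place: 2,6-dichlorobenzyl in place of 2,6-dichlorophenyl on a saturated chain carbon bound to an aromatic carbon. All three measured steps vary the group on the aromatic amide ring and leave the rest of the molecule untouched, so none of them bears on a change at the saturated chain carbon bound to an aromatic carbon. The series holds no case in which the 2,6-dichlorophenyl is replaced by 2,6-dichlorobenzyl, and the size and direction of the step must be taken as open. A step of a 2.9-fold higher number from compound 3 to compound 4 (0.46 log units; beyond the scatter) is expected for compound 4, with wide uncertainty in both directions. Compound 4 is estimated at 400 nM in this assay, with a range from 100 nM to 2000 nM.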

Compound 4, half-maximal inhibitory concentration: > 4000 nM
Compound 4: only a limit was reported (the forecaster's own chance of this, stated with the estimate: 10%); at least 10-fold (1.00 log units) between middle value and limit.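

Up to now only the group on the aromatic amide ring had varied, so this is the first reading at the saturated chain carbon bound to an aromatic carbon. In this assay, among these compounds, 2,6-dichlorobenzyl in place of 2,6-dichlorophenyl gives an at least 28-fold higher number from compound 3 to compound 4 (1.45 log units; beyond the scatter) and shows that this place is not a free one: a change of one carbon here can undo the low number held by the trifluoromethyl compound, and the step ranks as large, like the largest step among the earlier compounds. The reading for compound 4, > 4000 nM, is a limit of the assay and not a number, and compound 2 sits at the same limit: the limit of > 4000 nM in this assay, at which 2 of the 4 values shown sit.

With a single pair at this place, the compounds shown cannot tell whether the step is tied to chain length as such or would also appear with another link, such as an ether oxygen or an amine in the chain. They also leave open whether the 2,6-dichlorobenzyl group would behave the same way with tert-butyl on the aromatic amide ring, or whether a benzyl group without the two chlorines would give a similar reading.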